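Ring Swap on the Thiocarbonyl Carbon: Expecting Compound 4

A few compounds are considered here, and "the series" means these few. Any claim that something is new, unique, unknown or untested is made for them only; others in the source may bear on it.

Compound 1 `N/C(=N\NC(=S)N1CCOCC1)c1ccccn1`: 43.1%
Compound 2 `Cc1ccnc(/C(N)=N/NC(=S)N2CCOCC2)c1`: 35.5%
Compound 3 `Cc1ccnc(/C(N)=N/NC(=S)N2CCCCCC2)c1`: 36.1%

In a functional assay on A-431 cells (Homo sapiens) for cytotoxicity, read by MTT assay, with a stated time of 72 h, tested at 3 uM (on this read-out higher numbers stand for more inhibition of growth at the one concentration tested and lower numbers for less inhibition of growth), compound 2 gives the lowest of the three numbers, though every gap to it lies within the scatter. The step of a number 7.6 percentage points lower from compound 1 to compound 2 (within the scatter) adds only a methyl group and is itself within the scatter. Compound 3 carries a different ring on the thiocarbonyl carbon, and compound 3 gives 36.1%, close to compound 2. Compound 4 `Cc1ccnc(/C(N)=N/NC(=S)N2CCCC2)c1` is the unmeasured analogue; the change is pyrrolidin-1-yl in place of morpholin-4-yl on a thiocarbonyl carbon. For the measured compounds named here, no measured step covers this exact swap, but the nearby ring change between compound 2 and compound 3 left the numbers close. The expected step of a number 0.5 percentage points higher from compound 2 to compound 4 (within the scatter) is therefore small, likely within the scatter. Compound 4 is estimated at 36%, with a range from 26% to 46%.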

Compound 4, percent growth inhibition at one concentration: 63%
Beside the measured number, compound 4's estimate is 27 percentage points below it, and the stated range ends below it.
By their numbers in this assay, from the lowest: compounds 2, 3 and 1 (each within the scatter of the next); then compound 4.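

In this assay, pyrrolidin-1-yl in place of morpholin-4-yl on a thiocarbonyl carbon gives a number 27.5 percentage points higher from compound 2 to compound 4 (beyond the scatter), so the ring at this position can move the read-out well beyond the scatter. No earlier step had shown this, and the ring in compound 3 had left the number within the scatter of compound 2. Nothing available here accounts for the rise.

Still open, as far as these compounds go, is whether piperidin-1-yl or an open-chain diethylamino group on the same carbon would keep this gain. From the compounds shown here alone, it is also open whether pyrrolidin-1-yl would do the same without the methyl on the aromatic ring.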